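The source may hold more compounds than are shown below. What is called first, only, known or untested is meant among the compounds shown, and "the series" means these compounds.

Measured so far:

- compound 1, `O=C(Nc1ccccc1C(F)(F)F)C1CCc2ccccc2N1C(=O)c1ccccc1`: 8090 nM
- compound 2, `CCCCCCCCC(=O)N1c2ccccc2CCC1C(=O)Nc1ccccc1C(F)(F)F`: 8330 nM
- compound 3, `COc1ccc(NC(=O)C2CCc3ccccc3N2)cc1`: 38000 nM

In a functional assay on ACHN cells (Homo sapiens) for cytotoxicity, read by sulforhodamine B assay, with a stated time of 72 h (a higher number here means a weaker inhibitor of growth, a lower number a stronger inhibitor of growth), compound 3 gives the highest of the three numbers, standing beyond the scatter from compound 2 and from compound 1, so of the three it is the weakest inhibitor of growth. Compound 4, `O=C(Nc1ccccc1)C1CCc2ccccc2N1`, differs from compound 3 in one place: hydrogen in place of methoxy on an aromatic carbon, on an aromatic carbon of a six-membered aromatic ring of carbon only.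

Among the compounds with values here, only one measured step exists, a 1.0-fold higher number from compound 1 to compound 2 (0.01 log units; within the scatter), and it concerns the group on a carbonyl carbon, not a group on the aromatic ring, so it does not bear directly on the change in hand. Compound 3 also lacks the trifluoromethyl and the carbonyl substituent on the ring nitrogen that compounds 1 and 2 carry, so nothing in the data shows what removing a methoxy from this ring does. The expectation is therefore a step of no particular direction, no change at the digits printed from compound 3 to compound 4 (within the scatter), within the scatter. Compound 4 is estimated at 38000 nM, in the range 15000 nM to 95000 nM.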

Compound 4, concentration for 50% growth inhibition: 72900 nM
The estimate for compound 4 lay 1.9-fold (0.28 log units) below the measured number, within the range that was stated.
By their numbers in this assay, from the lowest: compounds 1 and 2 (each within the scatter of the next); then compounds 3 and 4 (each within the scatter of the next).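

Putting hydrogen in place of methoxy on an aromatic carbon, para to a large group, gives a 1.9-fold higher number from compound 3 to compound 4 (0.28 log units; within the scatter) in this assay. Within the data shown here, this is the first step that reads a group on this ring directly, and on this pair the methoxy cannot be told apart from hydrogen. No measurement at hand speaks to why the two compounds read alike.

From the compounds shown here alone, whether another group at this position, such as an amine, a carboxylic acid or a nitrile, would give a step beyond the scatter remains open. Also open, going by these compounds, is whether the same swap of methoxy for hydrogen would read alike in compounds that carry the acyl group on the ring nitrogen, as compound 1 and compound 2 do.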